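The source may report more compounds than this note shows. Statements on the series, on what has been measured and on what is new or still open speak of the compounds shown alone.

Measured compounds:
- compound 1, `COc1cc(N/C=C\C(=O)c2cn(-c3ccccc3)nc2-c2ccc(F)cc2)cc(OC)c1OC`, gives 9350 nM in a functional assay on A549 cells (Homo sapiens) for antiproliferative activity, read by MTT assay, with a stated time of 48 h; a lower number here means a stronger inhibitor, a higher number a weaker inhibitor
- compound 2, `COc1cc(N/C=C\C(=O)c2cn(-c3ccccc3)nc2-c2ccc(Cl)cc2)cc(OC)c1OC`, gives 5640 nM in this assay
- compound 3, `COc1ccc(-c2nn(-c3ccccc3)cc2C(=O)/C=C\Nc2ccc(F)cc2)cc1`, gives 3980 nM in this assay

Compound 1 and compound 2 share one core and differ only by the change (chloro in place of fluoro on an aromatic carbon). That change made the step of a 1.7-fold lower number from compound 1 to compound 2 (0.22 log units; within the scatter), so within this pair the swap of the halogen did not move the number beyond what repeated measurements would show anyway.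

Compound 3 is built on a different core; the difference between the two cores is not broken down here. Its number in this assay is the lowest of the three, yet its gap to compound 2 is within the scatter, so it cannot be called stronger than compound 2; only compound 1 stands clearly apart from it.

Compound 4, `COc1ccc(-c2nn(-c3ccccc3)cc2C(=O)/C=C\Nc2ccc(Cl)cc2)cc1`, has not been measured. For the measured compounds named here, it differs from compound 3 by chloro in place of fluoro on an aromatic carbon, which is the same change as the one from compound 1 to compound 2, at the same kind of place on the ring. Going by the values given here, for compound 4 the expected step is a 1.4-fold lower number from compound 3 to compound 4 (0.15 log units; within the scatter), because a 1.7-fold lower number from compound 1 to compound 2 (0.22 log units; within the scatter) is the only measured example of this change and it stayed small. Compound 4 is therefore estimated to give 2800 nM in this assay, with a likely range from 1200 nM to 6500 nM.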

Compound 4, half-maximal inhibitory concentration: 2970 nM
Estimate against measurement, compound 4: 1.1-fold (0.03 log units) below, and the stated range covers the measured number.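

In this assay, putting chloro in place of fluoro gives a 1.3-fold lower number from compound 3 to compound 4 (0.13 log units; within the scatter), so on this second core the swap again stays inside what repeated measurements would show anyway. Set beside the earlier case, the two steps agree: the same change on two cores in this assay, a 1.7-fold lower number (0.22 log units; within the scatter) from compound 1 to compound 2 and a 1.3-fold lower number (0.13 log units; within the scatter) from compound 3 to compound 4, 1.2-fold (0.09 log units) apart, within the scatter of two such steps. This shows that, across these two pairs, the change carries from one core to the other as a step too small to separate from noise, but it does not show that chloro beats fluoro on either core, and two pairs with such small steps are a weak test of transfer, since a step that barely registers on both cores would look the same whether or not the cores respond alike.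

The compounds shown carry only fluoro or chloro at this place, so it stays open whether bromo, a nitrile, an amine or a carboxylic acid there would move the number beyond the scatter. Also open, going by these compounds, is whether the swap would stay this small on a third core, or in any test other than this assay.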